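Removing one methoxy from the benzoyl group of compound 3

The source may report more compounds than this note shows. Statements on the series, on what has been measured and on what is new or still open speak of the compounds shown alone.

Measured so far:
compound 1 `COCc1ccccc1C(=O)c1oc2cc(-c3ccccc3)cc(O)c2c1C`: 0.1 ug/mL
compound 2 `Cc1c(C(=O)c2ccc(N(C)C)cc2)oc2cc(-c3ccccc3)cc(O)c12`: > 4 ug/mL
compound 3 `COc1ccc(OC)c(C(=O)c2oc3cc(-c4ccccc4)cc(O)c3c2C)c1`: 0.09 ug/mL

In a functional assay on WI-38 VA13 cells (Homo sapiens) for cytotoxicity (a higher number here means that more compound is needed for the effect, a lower number that less compound is needed), compound 1 gives 0.1 ug/mL and compound 3 gives 0.09 ug/mL; these two numbers sit within the usual scatter of each other. Compound 2 gives only a limit, > 4 ug/mL, not a number (the limit of > 4 ug/mL in this assay, at which 1 of the 3 values shown sits). Of the two numbers shown, compound 3 is therefore not set apart from compound 1. Among the measured compounds shown here, the single measured step, an at least 40-fold higher number from compound 1 to compound 2 (1.60 log units; beyond the scatter), is the only one recorded in this assay, and it concerns a different exchange on the carbonyl carbon, so it does not speak directly to the change now at hand.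

Compound 4 `COc1ccccc1C(=O)c1oc2cc(-c3ccccc3)cc(O)c2c1C` differs from compound 3 by hydrogen in place of methoxy on an aromatic carbon, on an aromatic carbon of a six-membered aromatic ring of carbon only, meta to a large group and para to a methoxy group. What remains on that ring is a single methoxy group, which places compound 4 close to compound 1, whose value in this assay lies within the scatter of compound 3. For the measured compounds named here, no measured step bears on loss of this methoxy. The step expected is a 1.1-fold higher number from compound 3 to compound 4 (0.05 log units; within the scatter), within the scatter. Compound 4 is estimated at 0.1 ug/mL, range 0.04 ug/mL to 0.3 ug/mL.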

Compound 4, half-maximal effective concentration: 0.09 ug/mL
Beside the measured number, compound 4's estimate is 1.1-fold (0.05 log units) above it, within the range that was stated.
By their numbers in this assay, from the lowest: compounds 3, 4 and 1 (each within the scatter of the next). At a limit, above all of these: compound 2.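

In this assay, hydrogen in place of methoxy on this aromatic carbon, meta to a large group and para to a methoxy group, gives no change at the digits printed from compound 3 to compound 4 (within the scatter) and methoxy in place of methoxymethyl on an aromatic carbon gives a 1.1-fold lower number from compound 1 to compound 4 (0.05 log units; within the scatter), so the methoxy that leaves is not needed to keep a value of this order, and compound 1, compound 3 and compound 4 cannot be told apart in this assay. The exchange on the carbonyl carbon, 2-methoxyphenyl in place of 4-(dimethylamino)phenyl, gives an at least 44-fold lower number from compound 2 to compound 4 (1.64 log units; beyond the scatter) and thus shows a second large step to compound 2, now against the simplest member of the methoxy set. Compound 2 has a limit and not a number: the limit of > 4 ug/mL in this assay, at which 1 of the 4 values shown sits.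

Still open is whether that large step follows the dimethylamino group itself or the place it holds on the phenyl ring, and the compounds shown do not separate the two. Also open, as far as these compounds go, is what an unsubstituted phenyl, a carboxylic acid or a longer chain on this ring would give, since every low value here carries a methoxy or methoxymethyl group.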